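Swapping a Hydroxyphenyl for a Trifluoromethylphenyl on the Amide Chain

The compounds below may be only part of what the source reports. "The series", "measured", "known", "first", "only" and "open" are said of these compounds alone.

Of the compounds shown here, two have so far been measured in an assay on HEK293 cells for displacement of a labelled ligand from Melanocortin receptor 4 (Homo sapiens); a lower number here means a stronger inhibitor, a higher number a weaker inhibitor. Compound 1 `CCCCC(N)c1cc(C(F)(F)F)ccc1N1CCN(C(=O)CCc2ccc(Cl)cc2Cl)CC1` gives 190 nM in this assay. Compound 2 `CC(C)C[C@H](N)c1cc(C(F)(F)F)ccc1N1CCN(C(=O)CCc2ccccc2O)CC1` gives 3300 nM in this assay, the higher of the two numbers, and the gap between compound 2 and compound 1 lies beyond the usual scatter. Among the compounds with values here, no step between measured compounds that differ in a single place is available, so no counted step can be quoted.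

Compound 3 `CC(C)C[C@H](N)c1cc(C(F)(F)F)ccc1N1CCN(C(=O)CCc2cccc(C(F)(F)F)c2)CC1` has not yet been measured. Relative to compound 2 it carries 3-(trifluoromethyl)phenyl in place of 2-hydroxyphenyl on a saturated chain carbon, two bonds along the chain from a carbonyl carbon; the rest of the molecule, including the core of compound 2, is unchanged. Since compound 1, whose amide chain ends in its own substituted phenyl, gives 190 nM, a phenyl without the hydroxy donor seems compatible with a lower number. Compound 3 is therefore expected to give 450 nM in this assay, with a range from 120 nM to 1800 nM. That estimate means an expected step of a 7.3-fold lower number from compound 2 to compound 3 (0.87 log units; beyond the scatter), a drop beyond the scatter, though its size is uncertain.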

Compound 3, inhibition constant: 2200 nM
For compound 3 the middle estimate is 4.9-fold (0.69 log units) below the measured one; measured number outside the range, above it.
By their numbers in this assay, from the lowest: compound 1; then compounds 3 and 2 (each within the scatter of the next).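

In this assay, 3-(trifluoromethyl)phenyl in place of 2-hydroxyphenyl on a saturated chain carbon, two bonds along the chain from a carbonyl carbon, gives a 1.5-fold lower number from compound 2 to compound 3 (0.18 log units; within the scatter), so this read-out does not separate the two groups at this position. The exchange takes away the hydrogen-bond donor and the hydrogen-bond acceptor counted on 2-hydroxyphenyl and brings in a larger group with neither, yet the two numbers lie within the scatter of each other, so this pair gives no sign that the hydroxy group or the trifluoromethyl group sets the number here. No measurement at hand bears on why these two groups read alike.

Compound 1 differs from compound 2 and from compound 3 in more than one place, so its gaps to them cannot be read as steps, and what separates its number from theirs stays unassigned. Also open, as far as these compounds go, is how this position responds to other groups on the shared core of compound 2 and compound 3, such as a carboxylic acid or an amine on the phenyl ring, or a longer chain in this place.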